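A few compounds are considered here, and "the series" means these few. Any claim that something is new, unique, unknown or untested is made for them only; others in the source may bear on it.

Three amides sharing the same core have so far been examined in a functional assay on MDA-MB-231 cells (Homo sapiens) for antiproliferative activity, read by MTT assay, with stated times of 72 h and 4 h; a lower number here means a stronger inhibitor, a higher number a weaker inhibitor. Compound 1, with the structure `O=C(Nc1ccc(Cl)c(-c2nnc3c(Cl)cccn23)c1)c1ccccn1`, gives 92000 nM in this assay. Compound 2, `Cc1nc(C(=O)Nc2ccc(Cl)c(-c3nnc4c(Cl)cccn34)c2)cs1`, gives in this assay > 100000 nM, which is a limit of the assay and not a number. Compound 3, `O=C(Nc1ccc(Cl)c(-c2nnc3c(Cl)cccn23)c1)c1ccon1`, likewise gives in this assay > 100000 nM, again a limit rather than a number. Compound 3 thus stands at the weak end of what has been measured, beyond the range the assay resolves.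

The unmeasured compound 4, `O=C(Nc1ccc(Cl)c(-c2nnc3c(Cl)cccn23)c1)c1ccccc1`, differs from compound 3 by phenyl in place of 1,2-oxazol-3-yl on a carbonyl carbon. Among the measured compounds shown here, the steps that bear on this exchange of the ring on the carbonyl carbon are an at least 1.0-fold higher number from compound 1 to compound 2 (0.03 log units; that floor lies within the scatter) and an at least 1.0-fold higher number from compound 1 to compound 3 (0.03 log units; that floor lies within the scatter), both of which only set a floor that lies within the scatter, while a step that the two limits leave unreadable from compound 2 to compound 3. Since two of the three values sit at the limit of > 100000 nM in this assay, at which 2 of the 3 values shown sit, none of these ring exchanges has produced a readable shift in this assay.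

Compound 4 is therefore expected to remain weak, with an estimated a number no higher from compound 3 to compound 4 (the limit leaves the size open) in this assay that carries no direction beyond the scatter. The estimate for compound 4 is 100000 nM, with a range from 40000 nM to 250000 nM, and a substantial chance that only a limit is reported.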

Compound 4, half-maximal inhibitory concentration: 58200 nM
Compound 4: middle estimate off by 1.7-fold (0.24 log units), on the high side; the range from low to high includes it.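

With phenyl on the carbonyl carbon, this assay gives a number rather than a limit, so a ring of carbon only, with no hydrogen-bond acceptors, is enough to bring a value back within the readable range, as pyridin-2-yl also did in compound 1. The exchange of the five-membered rings for phenyl shows an at least 1.7-fold lower number from compound 3 to compound 4 (0.23 log units; that floor lies within the scatter) and an at least 1.7-fold lower number from compound 2 to compound 4 (0.23 log units; that floor lies within the scatter), and these are floors only, so they do not establish a real gain at this position, though the true size of either step could be larger. The comparison of the two six-membered rings gives a 1.6-fold lower number from compound 1 to compound 4 (0.20 log units; within the scatter), so removing the ring nitrogen of pyridin-2-yl has no effect that can be told from the scatter, and compound 1 and compound 4 cannot be put in order.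

On these data alone, whether any ring on this carbonyl carbon can move the value beyond the scatter stays open, and two of the compounds still give only a limit: the limit of > 100000 nM in this assay, at which 2 of the 4 values shown sit. It also stays open what a non-aromatic group such as cyclohexyl or an ethyl chain would do here, or a phenyl ring carrying an amine or a carboxylic acid.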